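The source may report more compounds than this note shows. Statements on the series, on what has been measured and on what is new or still open speak of the compounds shown alone.

Measured in a functional assay on PC-12 cells (Rattus norvegicus) for inhibition, read by sulforhodamine B assay; a higher number here means a weaker inhibitor, a lower number a stronger inhibitor:
- compound 1 `O=C1NC(=O)C(Cc2ccc(OCC3CCC3)cc2)S1`: > 100000 nM
- compound 2 `O=C1NC(=O)/C(=C/c2ccc(OCC3CCC3)cc2)S1`: 13000 nM

In this assay compound 1 reads > 100000 nM, which is a limit of the assay and not a number. This is the limit of > 100000 nM in this assay, at which 1 of the 2 values shown sits. Compound 2, in contrast, gives a true number, 13000 nM.

Compound 3 `O=C1NC(=O)C(Cc2ccc(OCc3ccccc3)cc2)S1` keeps the core of compound 1 and alters one group: phenyl in place of cyclobutyl on a saturated chain carbon bound to an oxygen on an aromatic ring. In words, this is phenyl in place of cyclobutyl on a saturated chain carbon bound to an oxygen on an aromatic ring, so cyclobutylmethyl becomes benzyl.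

Within the data shown here, no measured pair shows what this swap does, so any expectation is loose. A small move towards stronger inhibition, meaning a lower number in this assay, is expected, and compound 3 may also end up reported only as a limit. A large gain is not expected, since even compound 2 reaches only 13000 nM. The expected change is an at least 1.2-fold lower number from compound 1 to compound 3 (0.09 log units; that floor lies within the scatter). The estimate for compound 3 is 80000 nM, with an expected range of 30000 nM to 200000 nM.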

Compound 3, half-maximal inhibitory concentration: > 100000 nM
Compound 3 gave a limit, no number (the forecaster's own chance of this, stated with the estimate: 50%); middle value at least 1.2-fold (0.09 log units) from the limit.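

Compound 1 and compound 3 both end at a limit in this assay and not at a number, so the swap from cyclobutylmethyl to benzyl cannot be read as a step: the limit of > 100000 nM in this assay, at which 2 of the 3 values shown sit.

The compounds shown leave open whether this swap changes inhibition at all, and what it does in a compound that gives a true number, such as compound 2.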